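The compounds below may be only part of what the source reports. "The series", "measured", "known", "first", "only" and "open" are said of these compounds alone.

Measured so far in a functional assay on DU-145 cells (Homo sapiens) for cytotoxicity, read by CCK-8 assay and cell counting, with a stated time of 2 days; a higher number here means a weaker inhibitor, a lower number a stronger inhibitor:

compound 1 `Oc1ccc(-c2cc(-c3ccc(Cl)cc3)nc(-c3cccnc3)c2)cc1`: 22800 nM
compound 2 `Oc1ccc(-c2cc(-c3ccc(Cl)cc3)nc(-c3cccs3)c2)cc1`: 7660 nM
compound 3 `Oc1cccc(-c2cc(-c3ccc(Cl)cc3)nc(-c3ccccn3)c2)c1`: 8090 nM

Compound 3 stands second highest of the three numbers; compound 2 lies within the scatter of it, while compound 1 lies beyond the scatter above it. Going by the values given here, the one step with a single change, a 3.0-fold lower number from compound 1 to compound 2 (0.47 log units; beyond the scatter), concerns a different position and does not bear on the change to compound 4 `Oc1ccc(-c2cc(-c3ccc(Cl)cc3)nc(-c3ccccn3)c2)cc1`, which is 4-hydroxyphenyl in place of 3-hydroxyphenyl on an aromatic carbon. Among the compounds with values here, no measured pair shows the same hydroxyphenyl shift, so nothing known here argues for a move in either direction in this assay . The expectation is therefore a step of a 1.0-fold lower number from compound 3 to compound 4 (0.00 log units; within the scatter) that stays within the scatter. Compound 4 is estimated at 8000 nM, with a range from 3000 nM to 22000 nM.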

Compound 4, half-maximal inhibitory concentration: 22500 nM
The estimate for compound 4 lay 2.8-fold (0.45 log units) below the measured number; the whole stated range lies below it.
By their numbers in this assay, from the lowest: compounds 2 and 3 (each within the scatter of the next); then compounds 4 and 1 (each within the scatter of the next).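

In this assay, moving the hydroxyl matters at this position: 4-hydroxyphenyl in place of 3-hydroxyphenyl gives a 2.8-fold higher number from compound 3 to compound 4 (0.44 log units; beyond the scatter). With 4-hydroxyphenyl held, pyridin-2-yl in place of thiophen-2-yl gives a 2.9-fold higher number from compound 2 to compound 4 (0.47 log units; beyond the scatter), while pyridin-2-yl in place of pyridin-3-yl gives a 1.0-fold lower number from compound 1 to compound 4 (0.01 log units; within the scatter), so the two pyridinyl groups cannot be told apart. No evidence on hand accounts for these steps. As far as these compounds go, it remains open whether the hydroxyphenyl shift holds with thiophen-2-yl or pyridin-3-yl in the core. From the compounds shown here alone, an amine or a carboxylic acid in place of the hydroxyl also remains untested in these data.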